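The compounds below may be only part of what the source reports. "The series", "measured", "known", "first", "only" and "open" are said of these compounds alone.

Of the compounds shown here, three have been measured in a functional assay on CHO cells for agonist activity at Free fatty acid receptor 1 (Homo sapiens), read by FLIPR and calcium flux, in the presence of a further agent that is not named here; on this read-out higher numbers stand for an effect only at larger amounts of compound and lower numbers for an effect already at smaller amounts. Compound 1 `Cc1ccc(-c2noc(COc3ccc(CCC(=O)O)cc3)n2)cc1` gives 300 nM, compound 2 `COc1cccc(-c2noc(COc3ccc(CCC(=O)O)cc3)n2)c1` gives 2670 nM, and compound 3 `CC(Oc1ccc(CCC(=O)O)cc1)c1nc(-c2cccs2)no1` gives 4000 nM. Compound 3 therefore carries the highest of the three numbers; its gap to compound 2 lies within the usual scatter, while its gap to compound 1 lies beyond it. Going by the values given here, the only measured step that exchanges the aryl group on the shared core is an 8.9-fold higher number from compound 1 to compound 2 (0.95 log units; beyond the scatter), where one substituted phenyl replaces another.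

Compound 4 `CC(Oc1ccc(CCC(=O)O)cc1)c1nc(-c2ccccc2)no1` differs from compound 3 in one place: phenyl in place of thiophen-2-yl on an aromatic carbon. Among the compounds with values here, no measured pair shows exactly this swap of a five-membered sulfur-containing ring for a bare six-membered carbon ring, so the step from compound 1 to compound 2 is only a loose guide to how much the number can move when this aryl group changes. A small shift is expected, with a 1.3-fold lower number from compound 3 to compound 4 (0.12 log units; within the scatter) lying within or only just beyond the scatter. Compound 4 is estimated at 3000 nM, in a range from 1000 nM to 9000 nM.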

Compound 4, half-maximal effective concentration: 2390 nM
For compound 4 the middle estimate is 1.3-fold (0.10 log units) above the measured one; the range from low to high includes it.
By their numbers in this assay, from the lowest: compound 1; then compounds 4, 2 and 3 (each within the scatter of the next).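

On the aromatic carbon of the five-membered ring with two nitrogens and one oxygen, exchanging thiophen-2-yl for phenyl gives, in this assay, a 1.7-fold lower number from compound 3 to compound 4 (0.22 log units; within the scatter), so the two rings cannot be told apart on this read-out. Here, a one-atom larger ring without sulfur leaves the number within the scatter, unlike the exchange of substituted phenyl groups on the related core, which gave an 8.9-fold higher number from compound 1 to compound 2 (0.95 log units; beyond the scatter). Nothing at hand explains why these two rings read alike.

Going by these compounds alone, with only this one pair, it remains open whether any other unsubstituted aromatic ring would behave the same way at this position. From the compounds shown here alone, it is also open whether an amine or a nitrile on the phenyl of compound 4 would move the number beyond the scatter.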